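This account rests on a few compounds, and the source may have more. Where it says the series, first, only, none or still open, it means among the compounds named here.

Measured in a physicochemical assay for lipophilicity, at pH 3; on this read-out lower numbers stand for lower lipophilicity and higher numbers for higher lipophilicity:

Compound 1, `CC(C)Nc1nc(NCc2ccco2)c2cccc(Cl)c2n1`: 2.38
Compound 2, `CC(C)Nc1nc(NCc2ccco2)c2c(Cl)cccc2n1`: 2.62
Compound 3, `Cc1cccc2c(NCc3ccco3)nc(NC(C)C)nc12`: 1.57

Compound 1 and compound 2 are built from the same atoms joined differently; the difference between the two cores is not broken down here, and in this assay the values of compound 1 and compound 2 lie within the usual scatter of each other. Compound 3 differs from compound 1 by one change, (methyl in place of chloro on an aromatic carbon), and that change gave a number 0.81 log units lower from compound 1 to compound 3 (beyond the scatter).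

Compound 4, `Cc1cccc2nc(NC(C)C)nc(NCc3ccco3)c12`, has not yet been measured. It differs from compound 2 by the same change, (methyl in place of chloro on an aromatic carbon). Within the data shown here, because the single example of this change, a number 0.81 log units lower from compound 1 to compound 3 (beyond the scatter), lowered the read-out clearly, a step of similar size is expected here, namely a number 0.81 log units lower from compound 2 to compound 4 (beyond the scatter). For compound 4 the expected value in this assay is therefore 1.81, estimated to fall between 1.45 and 2.15.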

Compound 4, distribution coefficient: 2.44
The estimate for compound 4 lay 0.63 log units below the measured number, outside the stated range (above it).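

In this assay, methyl in place of chloro on an aromatic carbon gave a number 0.81 log units lower from compound 1 to compound 3 (beyond the scatter) on one core, yet a number 0.18 log units lower from compound 2 to compound 4 (within the scatter) on the other. This pair of steps shows that in this series the size of the step on one core cannot simply be carried over to the other, but two pairs give no rule for any further core. Nothing shown here accounts for the difference between the two pairs.

The compounds shown leave open whether a methoxy group or an amine in place of chloro would also differ between the two cores. They also leave open whether a third core would follow compound 1 and compound 3 or compound 2 and compound 4.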